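Dropping a Methyl from the Hydroxyphenyl Amide

The compounds below may be only part of what the source reports. "The series", "measured", "known", "first", "only" and "open" are said of these compounds alone.

Of the compounds shown here, three sharing one core have been measured in an in vitro ADME assay on microsomes from liver (Homo sapiens) for metabolic stability; a lower number here means slower removal, a higher number faster removal of the compound. Compound 1 `O=C(C=C1CCN(C(=O)c2cccc(F)c2)CC1)N[C@@H]1CCN(Cc2ccc3cc(F)ccc3c2)C1` gives 459 mL/min/kg. Compound 2 `Cc1ccc(C(=O)N2CCC(=CC(=O)N[C@@H]3CCN(Cc4ccc5cc(F)ccc5c4)C3)CC2)c(O)c1` gives 156 mL/min/kg, and compound 3 `O=C(C=C1CCN(C(=O)c2ccc(Cl)cc2O)CC1)N[C@@H]1CCN(Cc2ccc3cc(F)ccc3c2)C1` gives 87 mL/min/kg. Compound 2 stands second highest of the three: its nearest neighbour is compound 3, reached by a 1.8-fold lower number from compound 2 to compound 3 (0.25 log units; within the scatter), a difference within the scatter, while compound 1 lies furthest away, the step of a 2.9-fold lower number from compound 1 to compound 2 (0.47 log units; beyond the scatter) being beyond the scatter. Compound 4 `O=C(C=C1CCN(C(=O)c2ccccc2O)CC1)N[C@@H]1CCN(Cc2ccc3cc(F)ccc3c2)C1` differs from compound 2 in one place: hydrogen in place of methyl on an aromatic carbon. Within the data shown here, no measured step removes a methyl outright, so the closest guide is the exchange of that methyl for chloro, a 1.8-fold lower number from compound 2 to compound 3 (0.25 log units; within the scatter), which stayed within the scatter; the larger steps of a 2.9-fold lower number from compound 1 to compound 2 (0.47 log units; beyond the scatter) and a 5.3-fold lower number from compound 1 to compound 3 (0.72 log units; beyond the scatter) concern a different part of the molecule. A small step, if any, is therefore expected in this assay. For compound 4 the estimate is 170 mL/min/kg, with a range from 85 mL/min/kg to 340 mL/min/kg, which corresponds to an expected step of a 1.1-fold higher number from compound 2 to compound 4 (0.04 log units; within the scatter).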

Compound 4, clearance: < 64 mL/min/kg
Compound 4 gave a limit, no number; the forecaster's own chance of this, stated with the estimate: 0%; middle value at least 2.6-fold (0.42 log units) away from the limit.
By their numbers in this assay, from the lowest: compounds 3 and 2 (each within the scatter of the next); then compound 1. At a limit, below all of these: compound 4.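

In this assay compound 4 gives a limit rather than a number: the limit of < 64 mL/min/kg in this assay, at which 1 of the 4 values shown sits. Even so, replacing the methyl with hydrogen produces a clear change, an at least 2.4-fold lower number from compound 2 to compound 4 (0.38 log units; beyond the scatter), so this position matters in a way the exchange of methyl for chloro, which stayed within the scatter, did not reveal. Exchanging chloro for hydrogen gives an at least 1.3-fold lower number from compound 3 to compound 4 (0.13 log units; that floor lies within the scatter), a floor that does not settle whether these two compounds truly differ, while exchanging the whole 3-fluorophenyl for 2-hydroxyphenyl gives an at least 7.1-fold lower number from compound 1 to compound 4 (0.85 log units; beyond the scatter).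

From the compounds shown here alone, the true value for compound 4 remains unknown, so the full size of these steps is still open. Also open, going by these compounds, is how the number would respond to other groups at this position, such as an amine, a methoxy group or a longer chain like ethyl.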